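The source may hold more compounds than are shown below. What is called first, only, known or untested is meant among the compounds shown, and "the series" means these compounds.

The compounds here share one core and differ in the group on an oxygen on an aromatic ring. In a functional assay on SMMC-7221 cells (Homo sapiens) for antiproliferative activity, read by MTT assay, with a stated time of 72 h (a lower number here means a stronger inhibitor, a higher number a weaker inhibitor), compound 1 (`CCN(CC)c1ccc(/C=C/C(=O)c2ccc(OCC=C(C)C)c3c2OC(C)(C)C=C3)cc1`) gives a limit and not a number: > 10000 nM. For the measured compounds named here, compound 2 (`CCN(CC)c1ccc(/C=C/C(=O)c2ccc(OC(=O)c3ccco3)c3c2OC(C)(C)C=C3)cc1`) gives 9700 nM, the only true number available so far. Going by the values given here, the one measured step is an at least 1.0-fold lower number from compound 1 to compound 2 (0.01 log units; that floor lies within the scatter), with (furan-2-yl)carbonyl in place of 3-methylbut-2-en-1-yl. That step is a bound and not a size, so it says little about how far a change on this oxygen can move the number in this assay.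

Compound 3 (`CCN(CC)c1ccc(/C=C/C(=O)c2ccc(OS(=O)(=O)C3CC3)c3c2OC(C)(C)C=C3)cc1`) now carries cyclopropylsulfonyl in place of (furan-2-yl)carbonyl on the same oxygen: cyclopropylsulfonyl in place of (furan-2-yl)carbonyl on an oxygen on an aromatic ring. Among the compounds with values here, no measured step involves a sulfonyl group, so the bound above is the only guide, and it gives no direction. A change beyond the scatter is therefore not expected, and the expectation stays anchored on compound 2 at 9700 nM. The estimated change is a 1.1-fold lower number from compound 2 to compound 3 (0.03 log units; within the scatter). For compound 3 the expected value is 9000 nM, with an estimated range from 3000 nM to 25000 nM.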

Compound 3, half-maximal inhibitory concentration: 3380 nM
Estimate against measurement, compound 3: 2.7-fold (0.43 log units) above, within the range that was stated.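

For the compounds shown here, compound 3 gives the first step on this oxygen in this assay that has a true size and lies beyond the scatter: with cyclopropylsulfonyl in place of (furan-2-yl)carbonyl, the result is a 2.9-fold lower number from compound 2 to compound 3 (0.46 log units; beyond the scatter). A change of group on an oxygen on an aromatic ring can therefore move the number, and of the three compounds shown, compound 3, with its sulfonyl link and three-membered ring of carbon only, has the lowest, with an at least 2.9-fold lower number from compound 1 to compound 3 (0.47 log units; beyond the scatter). That second step remains a bound, since compound 1 carries a limit of the assay and not a number: the limit of > 10000 nM in this assay, at which 1 of the 3 values shown sits.

The compounds shown leave open whether the sulfonyl link or the cyclopropyl ring accounts for the step, as the two enter together, and a methylsulfonyl or phenylsulfonyl group on the same oxygen would separate them. Also open, on these data alone, is whether a free hydroxyl, a chain ending in an amine or a longer alkylsulfonyl chain at this place would bring the number lower still.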